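The source may hold more compounds than are shown below. What is called first, only, known or untested is meant among the compounds shown, and "the series" means these compounds.

Compound 1 `CC(=O)c1cc(C(=O)N[C@@H](C)Cn2ccc(-c3cc(F)c(C#N)c(Cl)c3)n2)n[nH]1`: "not determined" (no result reported)
Compound 2 `CC(Cn1ccc(-c2ccc(C#N)c(Cl)c2)n1)C(=O)Nc1cc[nH]n1`: > 30000 nM

In a functional assay on VCaP cells (Homo sapiens) for antiproliferative activity, read by CCK-8 assay, with a stated time of 6 days (a lower number here means a stronger inhibitor, a higher number a weaker inhibitor), compound 2 gives > 30000 nM, which is a limit of the assay and not a number. Compound 3 `CC(Cn1ccc(-c2ccc(C#N)c(Cl)c2)n1)C(=O)Nc1cccc(C(C)O)c1` carries 3-(1-hydroxyethyl)phenyl in place of 1H-pyrazol-3-yl on an amide-type nitrogen. For the measured compounds named here, no measured pair of compounds shows how large such a change might be, so any forecast is loose. A moderate move toward stronger inhibition is expected, estimated as an at least 3.0-fold lower number from compound 2 to compound 3 (0.47 log units; beyond the scatter). A result that again reaches the limit would not be surprising. For compound 3 the estimated value is 10000 nM, with an expected range from 2000 nM to 30000 nM.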

Compound 3, half-maximal inhibitory concentration: > 30000 nM
Compound 3: only a limit was reported (the forecaster's own chance of this, stated with the estimate: 45%); middle value at least 3.0-fold (0.47 log units) from the limit.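

Compound 2 and compound 3 both end at a limit and not at a number, so no step between them can be read: the limit of > 30000 nM in this assay, at which 2 of the 3 values shown sit.

On these data alone, how 1H-pyrazol-3-yl and 3-(1-hydroxyethyl)phenyl truly compare on the amide-type nitrogen stays open.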